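Series notes: aryl substituent change on the urea, compound 4

A few compounds are considered here, and "the series" means these few. Any claim that something is new, unique, unknown or untested is made for them only; others in the source may bear on it.

In an ADME assay on the whole organism with Oryza sativa as the target, tested at 0.1 uM (on this read-out higher numbers stand for a weaker effect at the one concentration tested and lower numbers for a stronger effect), compound 2, `CC(C)c1cccc(NC(=O)N[C@@H](C)c2ccccc2)c1`, gives 95%, the second highest of the three numbers in hand. Compound 3, `CCCCCc1ccc(NC(=O)N[C@H](C)c2ccccc2)cc1`, gives 100%, and the two values lie within the scatter of each other. Compound 1, `CC(C)c1cccc(NC(=O)N[C@H](C)c2ccccc2)c1`, gives 74%, which is the furthest of the three from compound 2. For the measured compounds named here, the only measured step is a number 21 percentage points higher from compound 1 to compound 2 (beyond the scatter), and it rests on (the fact that compounds 1 and 2 differ only in the configuration as drawn).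

Compound 4, `CC(=O)c1cccc(NC(=O)N[C@@H](C)c2ccccc2)c1`, is not yet measured. It differs from compound 2 by acetyl in place of isopropyl on an aromatic carbon. Going by the values given here, no measured step concerns a substituent on this aromatic ring; the one measured step is a change of configuration alone and does not bear on the present change. No step beyond the scatter is therefore expected in this assay for this change. Compound 4 is expected to give 90%, with a range from 70% to 100%. The expected step is a number 5 percentage points lower from compound 2 to compound 4 (within the scatter), which should stay within the scatter of the measurement.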

Compound 4, a percentage reported as activity, at one concentration (the size of the read-out at that concentration, not a potency): 96%
Compound 4: the middle estimate sits 6 percentage points below what was measured; the measured number falls inside the stated range.
By their numbers in this assay, from the lowest: compound 1; then compounds 2, 4 and 3 (each within the scatter of the next).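

In this assay, for the compounds shown here, the exchange of isopropyl for acetyl on this aromatic carbon reads as a number 1 percentage points higher from compound 2 to compound 4 (within the scatter), the first measured step at a substituent on this ring and one that stays inside the scatter. The two groups are not alike in what is counted for them: acetyl has 1 hydrogen-bond acceptor and 1 double bond outside aromatic rings, isopropyl has 0 hydrogen-bond acceptors, and with the configuration held as drawn in compound 2, this difference is not accompanied by any step beyond the scatter at the one concentration tested. Going by these compounds alone, nothing in hand bears on the reason for this result, since the only supporting information concerns a change of configuration and not a change of substituent.

As far as these compounds go, whether the same exchange would also stay inside the scatter on the configuration of compound 1, which gives the lowest number so far (74%), remains open. Also open, from the compounds shown here alone, is whether an amine, a carboxylic acid or a longer chain on this aromatic carbon would produce a step beyond the scatter, as this single pair covers only acetyl and isopropyl.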